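From Fluoro to an Amino Ester Group

The compounds below may be only part of what the source reports. "The series", "measured", "known", "first", "only" and "open" are said of these compounds alone.

Measured so far in a functional assay on DU-145 cells (Homo sapiens) for cytotoxicity, read by trypan blue exclusion, with a stated time of 96 h (a higher number here means a weaker inhibitor, a lower number a stronger inhibitor), are three compounds:
Compound 1 `COc1cc(OC)c(/C=C/S(=O)(=O)Nc2ccc(OC)c(F)c2)c(OC)c1` gives 200 nM
Compound 2 `COc1ccc(NS(=O)(=O)/C=C/c2c(OC)cc(OCCCC(=O)O)cc2OC)cc1[N+](=O)[O-]` gives 100000 nM
Compound 3 `COc1ccc(NS(=O)(=O)/C=C/c2c(OC)cc(OCCCC(=O)O)cc2OC)cc1N` gives 10000 nM

Compound 1 has the lowest number of the three in this assay and is the strongest inhibitor among them, with both gaps beyond the scatter. Compound 4 `COC(=O)CNc1cc(NS(=O)(=O)/C=C/c2c(OC)cc(OC)cc2OC)ccc1OC` keeps the rest of compound 1 and changes one group, with ((methoxycarbonyl)methyl)amino in place of fluoro on an aromatic carbon, ortho to a methoxy group: ((methoxycarbonyl)methyl)amino in place of fluoro on an aromatic carbon and nothing else differs.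

Among the measured compounds shown here, only one measured step bears on this change, and only loosely. Amino in place of nitro on an aromatic carbon gave a 10-fold lower number from compound 2 to compound 3 (1.00 log units; beyond the scatter) and that modest step shows that a swap at this place can move the number beyond the scatter. However, compound 2 and compound 3 also differ from compound 1 elsewhere, and no measured compound carries the entering group. A modest rise is therefore the cautious expectation. The expected step is a 1.3-fold lower number from compound 1 to compound 4 (0.12 log units; within the scatter) and its size remains uncertain. For compound 4 the estimated value is 150 nM with an expected range from 30 nM to 800 nM in this assay.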

Compound 4, half-maximal inhibitory concentration: 350 nM
The estimate for compound 4 lay 2.3-fold (0.37 log units) below the measured number; measured number inside the range.
By their numbers in this assay, from the lowest: compounds 1 and 4 (each within the scatter of the next); then compound 3; then compound 2.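

In this assay the exchange of fluoro for ((methoxycarbonyl)methyl)amino gives a 1.8-fold higher number from compound 1 to compound 4 (0.24 log units; within the scatter) on the core of compound 1. This position, an aromatic carbon ortho to a methoxy group, therefore accepts a group of 6 heavy atoms in place of a single fluorine with no step beyond the scatter, something the nitro-to-amino pair could not show, since it sits on a core with a different chain. No measurement at hand gives a cause for this result.

The compounds shown leave open whether a plain amino group, or a carboxylic acid in place of the methyl ester, would keep the number within the scatter of compound 1 at this position. They also leave open how a longer chain between the amino nitrogen and the ester would fare.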